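Swapping the five-membered ring on the shared core

This account rests on a few compounds, and the source may have more. Where it says the series, first, only, none or still open, it means among the compounds named here.

Measured so far:
compound 1 `Cc1noc(C)c1-c1cnc(N)c(Oc2ccc(C(=O)Nc3cccc(Cl)n3)cc2)n1`: 39300 nM
compound 2 `Cc1noc(C)c1-c1cnc(N)c(Oc2ccc(C(=O)Nc3ccc(Cl)cn3)cc2)n1`: 9180 nM

Among the compounds with values here, in a functional assay on LoVo cells (Homo sapiens) for inhibition, read by MTT assay, with a stated time of 72 h (on this read-out lower numbers stand for stronger inhibition and higher numbers for weaker inhibition), compound 1 gives the highest of the two numbers; the only neighbour is compound 2, and the step of a 4.3-fold lower number from compound 1 to compound 2 (0.63 log units; beyond the scatter) concerns a change on an amide-type nitrogen. Compound 3 `Cn1cc(-c2cnc(N)c(Oc3ccc(C(=O)Nc4cccc(Cl)n4)cc3)n2)cn1` instead alters the five-membered ring on the core: 1-methyl-1H-pyrazol-4-yl in place of 3,5-dimethyl-1,2-oxazol-4-yl on an aromatic carbon. Within the data shown here, no measured step bears on this change. The expectation for compound 3 is therefore no step beyond the scatter in this assay, with a wide range, giving 39300 nM (from 8000 nM to 150000 nM), a step of no change at the digits printed from compound 1 to compound 3 (within the scatter).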

Compound 3, half-maximal inhibitory concentration: 48600 nM
The estimate for compound 3 lay 1.2-fold (0.09 log units) below the measured number; the range from low to high includes it.
By their numbers in this assay, from the lowest: compound 2; then compounds 1 and 3 (each within the scatter of the next).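

Replacing 3,5-dimethyl-1,2-oxazol-4-yl with 1-methyl-1H-pyrazol-4-yl gives, in this assay, a 1.2-fold higher number from compound 1 to compound 3 (0.09 log units; within the scatter). With the 6-chloropyridin-2-yl amide held fixed, this read-out therefore does not separate these two five-membered rings at this aromatic carbon. No available evidence bears on this result.

Open, from the compounds shown here alone, is whether the same holds alongside the 5-chloropyridin-2-yl amide of compound 2. Also open, going by these compounds, is how a morpholine, an amine or a carboxylic acid would read at this carbon in place of the five-membered ring.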